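Direct Aryl Returns: Methoxyphenyl in Place of the Sulfonamide Arm

The compounds below may be only part of what the source reports. "The series", "measured", "known", "first", "only" and "open" are said of these compounds alone.

Compound 1 `O=C1O[C@H]([C@@H](O)Cn2cc(-c3cccc(O)c3)nn2)C(OCc2ccccc2)=C1OCc1ccccc1`: > 100000 nM
Compound 2 `O=C1O[C@H]([C@@H](O)Cn2cc(-c3cc(F)cc(F)c3)nn2)C(OCc2ccccc2)=C1OCc1ccccc1`: > 100000 nM
Compound 3 `O=C1O[C@H]([C@@H](O)Cn2cc(CNS(=O)(=O)c3ccc(F)cc3)nn2)C(OCc2ccccc2)=C1OCc1ccccc1`: 41100 nM

In a functional assay on SW-620 cells (Homo sapiens) for antiproliferative activity, read by MTT assay, with a stated time of 72 h (a lower number here means a stronger inhibitor, a higher number a weaker inhibitor), compound 1 reaches only a limit, > 100000 nM. Compound 2 likewise reaches only a limit, > 100000 nM. Among the measured compounds shown here, compound 3 gives the sole number, 41100 nM, and so stands alone on the measured side. Compound 4 `COc1ccc(-c2cn(C[C@H](O)[C@H]3OC(=O)C(OCc4ccccc4)=C3OCc3ccccc3)nn2)cc1` carries 4-methoxyphenyl in place of (((4-fluorophenyl)sulfonyl)amino)methyl on an aromatic carbon. The measured steps that bear on this run the opposite way: an at least 2.4-fold lower number from compound 1 to compound 3 (0.38 log units; beyond the scatter) and an at least 2.4-fold lower number from compound 2 to compound 3 (0.38 log units; beyond the scatter), each leaving an aryl ring joined directly to the core, with two of the three values sitting at the limit of > 100000 nM in this assay, at which 2 of the 3 values shown sit. Compound 4 restores a directly joined aryl, so a rise of at least that size is expected, a 2.4-fold higher number from compound 3 to compound 4 (0.39 log units; beyond the scatter), quite possibly back to the limit. Compound 4 is therefore estimated at 100000 nM, within 40000 nM to 300000 nM.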

Compound 4, half-maximal inhibitory concentration: 58200 nM
Compound 4: middle estimate off by 1.7-fold (0.24 log units), on the high side, and the stated range covers the measured number.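

At this aromatic carbon in this assay, a directly joined aryl ring does not by itself lead to the limit, and compound 4 goes against that pattern in compounds 1 and 2. The swap of the sulfonamide arm for 4-methoxyphenyl gives a 1.4-fold higher number from compound 3 to compound 4 (0.15 log units; within the scatter). The other two comparisons give an at least 1.7-fold lower number from compound 2 to compound 4 (0.23 log units; that floor lies within the scatter) and an at least 1.7-fold lower number from compound 1 to compound 4 (0.23 log units; that floor lies within the scatter), and neither floor shows a gain beyond the scatter, as both start from a limit: the limit of > 100000 nM in this assay, at which 2 of the 4 values shown sit.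

Still open, as far as these compounds go, is whether an amine or a carboxylic acid in place of the methoxy group on that phenyl ring would shift the number in this assay.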